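A Shorter Side Chain and Cell Growth Inhibition

This account rests on a few compounds, and the source may have more. Where it says the series, first, only, none or still open, it means among the compounds named here.

Three compounds have been measured in a functional assay on HL-60 cells (Homo sapiens) for antiproliferative activity, read by XTT assay, with a stated time of 72 h; a lower number here means a stronger inhibitor, a higher number a weaker inhibitor:
compound 1 `C=C(C)CCC[C@]1(C)C2=CCC[C@](C)(C[C@@H](OC(C)=O)C3=CC(=O)OC3O)[C@H]2CC[C@H]1C` gives 3200 nM;
compound 2 `C=C(C)CCC[C@]1(C)C2=CCC[C@](C)(C[C@H](O)C3=CC(=O)OC3O)[C@H]2CC[C@H]1C` gives 3000 nM;
compound 3 `C=C(C)CC[C@]1(C)C2=CCC[C@](C)(C[C@@H](OC(C)=O)C3=CC(=O)OC3O)[C@H]2CC[C@H]1C` gives 3300 nM.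

Compound 3 differs from compound 1 by a single change, (1-methylethenyl in place of 2-methylprop-2-en-1-yl on a saturated chain carbon, two bonds along the chain from a saturated ring carbon). That step, a 1.0-fold higher number from compound 1 to compound 3 (0.01 log units; within the scatter), left the number essentially unchanged. Compound 2 stands on a different core from compound 1; the difference between the two cores is not broken down here, and the two values sit close together.

Compound 4 `C=C(C)CC[C@]1(C)C2=CCC[C@](C)(C[C@H](O)C3=CC(=O)OC3O)[C@H]2CC[C@H]1C` has not yet been measured. It differs from compound 2 by 1-methylethenyl in place of 2-methylprop-2-en-1-yl on a saturated chain carbon, two bonds along the chain from a saturated ring carbon, the same change as from compound 1 to compound 3. Because the earlier step of a 1.0-fold higher number from compound 1 to compound 3 (0.01 log units; within the scatter) showed no movement, a similarly small step is expected here, a 1.0-fold higher number from compound 2 to compound 4 (0.01 log units; within the scatter). Compound 4 is therefore estimated at 3100 nM, with a likely range from 1500 nM to 6500 nM.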

Compound 4, half-maximal inhibitory concentration: 3200 nM
For compound 4 the middle estimate is 1.0-fold (0.01 log units) below the measured one, and the stated range covers the measured number.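

On the core of compound 2, putting 1-methylethenyl in place of 2-methylprop-2-en-1-yl gives a 1.1-fold higher number from compound 2 to compound 4 (0.03 log units; within the scatter). Set beside the earlier step, the change behaves alike on the two cores: the same change on two cores in this assay, a 1.0-fold higher number (0.01 log units; within the scatter) from compound 1 to compound 3 and a 1.1-fold higher number (0.03 log units; within the scatter) from compound 2 to compound 4, 1.0-fold (0.01 log units) apart, within the scatter of two such steps. This shows that the side chain can be shortened in this way on both cores without a measurable shift in the number, but neither step has a real effect to carry over, so it does not show that a larger effect would transfer, or that a third core would respond the same way.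

The compounds shown leave open whether a longer chain, or a side chain carrying an amine or a carboxylic acid, would move the number beyond the scatter.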